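Swapping the side group of compound 3

The source may report more compounds than this note shows. Statements on the series, on what has been measured and on what is new or still open speak of the compounds shown alone.

In an ADME assay on microsomes from liver (Homo sapiens) for metabolic stability, read by LC-MS, tested at 1 uM (on this read-out lower numbers stand for slow clearance and higher numbers for fast clearance), compound 3 `OC1(COc2ccc([C@H]3CC[C@]4(CC3)OOC3(O4)C4CC5CC(C4)CC3C5)cc2)CCNCC1` gives 16 mL.min-1.g-1. That stands level with compound 1 `O=S(=O)(c1ccc([C@H]2CC[C@]3(CC2)OOC2(O3)C3CC4CC(C3)CC2C4)cc1)N1CCNCC1`, which gives 16 mL.min-1.g-1. Compound 2 `NCCOCCOc1ccc([C@H]2CC[C@]3(CC2)OOC2(O3)C3CC4CC(C3)CC2C4)cc1` reports only a limit of the assay, < 7 mL.min-1.g-1, and not a number.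

Compound 4 `NC1CCN(S(=O)(=O)c2ccc([C@H]3CC[C@]4(CC3)OOC3(O4)C4CC5CC(C4)CC3C5)cc2)CC1` carries (4-aminopiperidin-1-yl)sulfonyl in place of the (4-hydroxypiperidin-4-yl)methoxy of compound 3, on an aromatic carbon, para to a large group: (4-aminopiperidin-1-yl)sulfonyl in place of (4-hydroxypiperidin-4-yl)methoxy on an aromatic carbon.

The most relevant measured step is no change at the digits printed from compound 1 to compound 3 (within the scatter). It exchanges the same (4-hydroxypiperidin-4-yl)methoxy for (piperazin-1-yl)sulfonyl, a group much like the one entering here. The steps of an at least 2.2-fold lower number from compound 1 to compound 2 (0.35 log units; beyond the scatter) and an at least 2.2-fold higher number from compound 2 to compound 3 (0.35 log units; beyond the scatter) are larger, but both run through the 2-(2-aminoethoxy)ethoxy group, which compound 4 does not carry, so they weigh less.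

A change beyond the scatter is therefore not expected in either direction, and the expected size is no change at the digits printed from compound 3 to compound 4 (within the scatter). Within the data shown here, with only three compounds as a guide, the range stays wide. For compound 4 the estimated clearance is 16 mL.min-1.g-1, with an expected range from 8 mL.min-1.g-1 to 32 mL.min-1.g-1.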

Compound 4, intrinsic clearance in microsomes: < 7 mL.min-1.g-1
Compound 4 was reported as a limit; the forecaster's own chance of this, stated with the estimate: 10%; middle value at least 2.2-fold (0.35 log units) away from the limit.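

Compound 4 reports only a limit of the assay, < 7 mL.min-1.g-1, and not a number. At this position, the sulfonyl link does not fix the clearance on its own: the ring on the sulfur matters, as the swap of piperazin-1-yl for 4-aminopiperidin-1-yl gives an at least 2.2-fold lower number from compound 1 to compound 4 (0.35 log units; beyond the scatter). The level values of compound 1 and compound 3 had hidden this, and exchanging the ether-linked group of compound 3 for a sulfonyl-linked one can in fact shift the read-out, as seen in an at least 2.2-fold lower number from compound 3 to compound 4 (0.35 log units; beyond the scatter). The step to compound 4 from compound 2 cannot be read: the limit of < 7 mL.min-1.g-1 in this assay, at which 2 of the 4 values shown sit.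

Going by these compounds, it remains open whether the amino group itself drives the lower number, which a 4-hydroxypiperidin-1-yl group on the sulfonyl sulfur would test. How a carboxylic acid at that ring position would read is also unknown.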